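The source may report more compounds than this note shows. Statements on the series, on what has been measured and on what is new or still open speak of the compounds shown alone.

Compound 1 `O=C(Nc1nc(-c2cccc(C(F)(F)F)c2)cs1)c1ccc([N+](=O)[O-])o1` is one of two compounds here with a number in an ADME assay on Vero cells (Chlorocebus sabaeus) for cytotoxicity, read by MTT assay, with a stated time of 72 h; a higher number here means a weaker inhibitor, a lower number a stronger inhibitor. In this assay compound 1 gives 23900 nM. Compound 3 `O=C(Nc1nc(-c2cccc(NC(=O)C3CCCCC3)c2)cs1)c1ccc([N+](=O)[O-])o1` gives 21900 nM, and the step of a 1.1-fold lower number from compound 1 to compound 3 (0.04 log units; within the scatter) lies within the scatter. Compound 2 `CC(C)(C)OC(=O)Nc1cccc(-c2csc(NC(=O)c3ccc([N+](=O)[O-])o3)n2)c1` gives "not determined" (no result reported) in this assay. Compound 4 `O=C(Nc1nc(-c2cccc(NS(=O)(=O)Cc3ccccc3)c2)cs1)c1ccc([N+](=O)[O-])o1` differs from compound 1 in one place: (benzylsulfonyl)amino in place of trifluoromethyl on an aromatic carbon. Among the measured compounds shown here, the one measured step that bears on this change is the one from compound 1 to compound 3, where a (cyclohexylcarbonyl)amino group also replaced trifluoromethyl on an aromatic carbon, and that step was a 1.1-fold lower number from compound 1 to compound 3 (0.04 log units; within the scatter). For the measured compounds named here, only a single comparison of this kind is known, and the group entering in compound 4 is not the same one, so the expectation rests on that one step alone. The step from compound 1 to compound 4 in this assay is therefore expected to be a 1.1-fold lower number from compound 1 to compound 4 (0.04 log units; within the scatter), with no change beyond the scatter. Compound 4 is estimated to give 22000 nM, within a range from 10000 nM to 50000 nM.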

Compound 4, half-maximal inhibitory concentration: 59300 nM
Compound 4: middle estimate off by 2.7-fold (0.43 log units), on the low side, outside the stated range (above it).
By their numbers in this assay, from the lowest: compounds 3 and 1 (each within the scatter of the next); then compound 4.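

In this assay this place on the aromatic ring no longer looks indifferent to what it carries: the earlier replacement of trifluoromethyl gave a 1.1-fold lower number from compound 1 to compound 3 (0.04 log units; within the scatter) but the benzylsulfonylamino replacement gives a 2.5-fold higher number from compound 1 to compound 4 (0.39 log units; beyond the scatter) and so clears the scatter, though only modestly. The nitrogen on the ring is shared by compound 3 and compound 4, and what it carries still matters, with benzylsulfonyl in place of cyclohexylcarbonyl giving a 2.7-fold higher number from compound 3 to compound 4 (0.43 log units; beyond the scatter) as a step of similar size. Nothing available here explains why these numbers differ.

On these data alone, whether the step belongs to the sulfonyl link or to the benzyl part stays open. A phenylacetyl or a methylsulfonyl group on that same nitrogen would separate the two, and a free amine in this place would show how the number behaves with neither attached.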